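The compounds below may be only part of what the source reports. "The series", "measured", "known", "first", "only" and "open" are said of these compounds alone.

Three compounds share one core and differ only in the group carried on an aromatic carbon of it. Compound 1 `CCCS(=O)(=O)Nc1ccc(F)c(C(=O)c2n[nH]c3ncc(-c4ccc(F)cc4)cc23)c1F` gives 2.1% in an assay for binding affinity to dual specificity mitogen-activated protein kinase kinase 4 (Homo sapiens), read by KINOMEscan, tested at 100 nM (a lower number here means a stronger effect, a higher number a weaker effect of the compound at the concentration tested), compound 2 `CCCS(=O)(=O)Nc1ccc(F)c(C(=O)c2n[nH]c3ncc(-c4ccccc4OC)cc23)c1F` gives 1.9% in this assay, and compound 3 `CCCS(=O)(=O)Nc1ccc(F)c(C(=O)c2n[nH]c3ncc(-c4ccc(N(C)C)cc4)cc23)c1F` gives 2.5% in this assay. Compound 3 carries the highest of these three numbers, yet the steps of a number 0.4 percentage points higher from compound 1 to compound 3 (within the scatter) and a number 0.6 percentage points higher from compound 2 to compound 3 (within the scatter) both lie within the scatter, so the three compounds cannot be told apart on this read-out. Compound 4 `CCCS(=O)(=O)Nc1ccc(F)c(C(=O)c2n[nH]c3ncc(-c4ccc(C(C)(C)C)cc4)cc23)c1F` has not yet been measured in this assay. It differs from compound 3 by tert-butyl in place of dimethylamino on an aromatic carbon. The measured steps that bear on this change, a number 0.4 percentage points higher from compound 1 to compound 3 (within the scatter) and a number 0.6 percentage points higher from compound 2 to compound 3 (within the scatter), were each within the scatter, and a number 0.2 percentage points lower from compound 1 to compound 2 (within the scatter) was as well, so every exchange of the group on this ring seen so far has left the read-out unmoved. No step beyond the scatter is therefore expected in this assay for compound 4, the estimated step being a number 0.1 percentage points higher from compound 3 to compound 4 (within the scatter). Compound 4 is expected to give 2.6% in this assay, within a range from 0.5% to 9%.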

Compound 4, a percentage reported as activity, at one concentration (the size of the read-out at that concentration, not a potency): 46%
The estimate for compound 4 lay 43.4 percentage points below the measured number, outside the stated range (above it).
By their numbers in this assay, from the lowest: compounds 2, 1 and 3 (each within the scatter of the next); then compound 4.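

In this assay the group on this ring does matter after all: tert-butyl in place of dimethylamino gives a number 43.5 percentage points higher from compound 3 to compound 4 (beyond the scatter) and the other two exchanges give a number 44.1 percentage points higher from compound 2 to compound 4 (beyond the scatter) and a number 43.9 percentage points higher from compound 1 to compound 4 (beyond the scatter) so all three steps to compound 4 are large. Compounds 1, 2 and 3 therefore did not mark the limit of what this position accepts, since the read-out stays unmoved across fluoro, 2-methoxyphenyl and dimethylamino but not with tert-butyl, a group of carbon only. Nothing available explains why this exchange has so large an effect.

The compounds shown leave open whether a smaller alkyl group on the same carbon, such as methyl or isopropyl, already moves the read-out or whether tert-butyl stands alone. They also leave open how trifluoromethyl or a cyclohexyl ring would behave there.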